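A few compounds are considered here, and "the series" means these few. Any claim that something is new, unique, unknown or untested is made for them only; others in the source may bear on it.

Measured compounds:
compound 1, `CCn1c(SCC(=O)Nc2ccc(/C(C)=N/O)cc2)nnc1-c1ccc(OC)c(OC)c1`, gives 65%
compound 2, `COc1ccc(-c2nnc(SCC(=O)Nc3ccc(/C(C)=N/O)cc3)n2-c2ccccc2)cc1OC`, gives 63%
compound 3, `CCn1c(SCC(=O)Nc2ccc(C(C)=O)cc2)nnc1-c1ccccc1`, gives 53%

All three numbers come from a functional assay on the whole organism (strain albino) for inhibition, with Rattus norvegicus as the target, read by paw edema, with stated times of 30 min and 2 h, at a dose of 0.28 mmol/kg by the oral route; on this read-out lower numbers stand for less inhibition and higher numbers for more inhibition at the one dose given (going by the name of the read-out). Among the measured compounds shown here, the one change present twice in the set is phenyl in place of ethyl on an aromatic nitrogen. Between the two measured members carrying it, the step was a number 2 percentage points lower from compound 1 to compound 2 (within the scatter), so within this assay the change left the read-out essentially where it was.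

Compound 3 holds the lowest of the three numbers. Its gap to compound 2 lies within the scatter; its gap to compound 1 lies beyond it. How the core of compound 3 differs from the core of compound 1 is not broken down here.

Compound 4, `CC(=O)c1ccc(NC(=O)CSc2nnc(-c3ccccc3)n2-c2ccccc2)cc1`, has not yet been measured. It arises from compound 3 by phenyl in place of ethyl on an aromatic nitrogen. The surroundings of the place are not the same word for word: in compound 1 the change sits next to the ring atom that bears a 3,4-dimethoxyphenyl group, whereas in compound 3 it sits next to the ring atom that bears a phenyl group. The change is therefore the same kind of change, not the same.

The expected step is a number 2 percentage points lower from compound 3 to compound 4 (within the scatter), resting on the earlier step of the same kind, a number 2 percentage points lower from compound 1 to compound 2 (within the scatter), and on the value of compound 3, 53%. For compound 4 the estimate in this assay is 51%, with a range from 40% to 62%.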

Compound 4, a percentage reported as inhibition, in the whole organism at one dose (the size of the read-out at that dose, not a potency): 49%
Compound 4: the middle estimate sits 2 percentage points above what was measured, and the stated range covers the measured number.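

In this assay, the step for phenyl in place of ethyl on an aromatic nitrogen was a number 4 percentage points lower from compound 3 to compound 4 (within the scatter), so on the core of compound 3, as on the core of compound 1, the change left the read-out essentially where it was. Set beside the earlier step, the change carried from one core to the other with no difference that can be told apart: the same change on two cores in this assay, a number 2 percentage points lower (within the scatter) from compound 1 to compound 2 and a number 4 percentage points lower (within the scatter) from compound 3 to compound 4, 2 percentage points apart, within the scatter of two such steps

This supports treating ethyl and phenyl at this place as interchangeable for this read-out on these two cores, but it does not show that the same would hold on any other core of the series, and with both steps within the scatter, a small real effect cannot be separated from none; as a single-dose read-out, it also says nothing about potency.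

Still open, going by these compounds, is how the read-out responds to other groups on that aromatic nitrogen, such as a longer chain, a benzyl group or a chain ending in an amine. Also open is what the oxime and the 3,4-dimethoxyphenyl group each contribute alone, as no pair shown differs in only one of these places.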